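A few compounds are considered here, and "the series" means these few. Any claim that something is new, unique, unknown or untested is made for them only; others in the source may bear on it.

Measured compounds in a functional assay on HEK293 cells for agonist activity at Bombesin receptor subtype-3 (Homo sapiens), read by luminescence and calcium flux, with a stated time of 10 min; a higher number here means that more compound is needed for the effect, a lower number that less compound is needed:
compound 1 `CCC(C)(C)Cc1c[nH]c(CCc2ccc(-c3cccc(C)n3)cc2)n1` gives 105 nM
compound 2 `CCC(C)(C)Cc1c[nH]c(CCc2ccc(-c3cnccn3)cc2)n1` gives 431 nM
compound 3 `CCC(C)(C)Cc1c[nH]c(CCc2ccc(-c3cccc(C#N)n3)cc2)n1` gives 193 nM

Among these three numbers compound 2 stands highest: compound 3 lies nearest to it, with a 2.2-fold lower number from compound 2 to compound 3 (0.35 log units; beyond the scatter), and compound 1 lies furthest, with a 4.1-fold higher number from compound 1 to compound 2 (0.61 log units; beyond the scatter) in the other direction. Between compound 1 and compound 3 the step is a 1.8-fold higher number from compound 1 to compound 3 (0.26 log units; within the scatter).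

Compound 4 `CCC(C)(C)Cc1c[nH]c(CCc2ccc(N3CCCCC3)cc2)n1` is not yet measured. Relative to compound 2 the change is piperidin-1-yl in place of pyrazin-2-yl on an aromatic carbon. Going by the values given here, no measured step covers the exchange of an aromatic ring for a non-aromatic one at this carbon; the steps that do exist all swap one six-membered aromatic ring for another, and they move the number modestly in either direction. The new change is larger in kind than any of them, so the outcome is uncertain and a step of at least modest size, most likely toward a higher number, is expected in this assay: a 1.9-fold higher number from compound 2 to compound 4 (0.27 log units; within the scatter). For compound 4 the estimate in this assay is 800 nM, with a range from 200 nM to 3200 nM.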

Compound 4, half-maximal effective concentration: 171 nM
Compound 4: middle estimate off by 4.7-fold (0.67 log units), on the high side; measured number below the stated range.
By their numbers in this assay, from the lowest: compounds 1, 4 and 3 (each within the scatter of the next); then compound 2.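

At this aromatic carbon, para to a large group, this assay shows that an aromatic ring is not needed: the six-membered non-aromatic piperidin-1-yl in place of pyrazin-2-yl gives a 2.5-fold lower number from compound 2 to compound 4 (0.40 log units; beyond the scatter) and so recovers what the pyrazine exchange had lost. Piperidin-1-yl cannot be told apart from the two pyridine groups, with a 1.1-fold lower number from compound 3 to compound 4 (0.05 log units; within the scatter) and a 1.6-fold higher number from compound 1 to compound 4 (0.21 log units; within the scatter) both printed within the scatter, which leaves pyrazin-2-yl as the only group shown that stands apart from the other three. Nothing at hand accounts for this result.

The compounds shown leave open whether the ring nitrogen of piperidin-1-yl matters, as a cyclohexyl group or a morpholine ring at the same carbon would test. They also leave open how an open-chain dimethylamino group, or a carboxylic acid carried on the piperidine ring, would move the number.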